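Oxime ester series: dimethoxyphenyl swap on a limit compound

A few compounds are considered here, and "the series" means these few. Any claim that something is new, unique, unknown or untested is made for them only; others in the source may bear on it.

The series is followed in a functional assay on HCC1954 cells (Homo sapiens) for antiproliferative activity, read by MTT assay, with a stated time of 72 h; a higher number here means a weaker inhibitor, a lower number a stronger inhibitor. Compound 2 `Nc1cccc(C(=O)Nc2cccc(C(=O)O/N=C3\CCCc4onc(-c5ccc(F)cc5)c43)c2)c1` sits at a limit of this assay, > 25000 nM, and no number is reached for it. Compound 1 `COc1ccc(-c2noc3c2/C(=N/OC(=O)c2cccc(NC(=O)c4cccc(F)c4)c2)CCC3)cc1OC`, which carries the 3,4-dimethoxyphenyl group together with a 3-fluorobenzamide, also returns a limit in this assay, > 25000 nM. Among the measured compounds shown here, both values shown so far thus sit at the same limit (the limit of > 25000 nM in this assay, at which 2 of the 2 values shown sit), and no measured step between two compounds is available to size any change.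

Compound 3 `COc1ccc(-c2noc3c2/C(=N/OC(=O)c2cccc(NC(=O)c4cccc(N)c4)c2)CCC3)cc1OC` is the unmeasured member. From compound 2 it differs in one place: 3,4-dimethoxyphenyl in place of 4-fluorophenyl on an aromatic carbon. The aminobenzamide end of compound 2 is kept; only the aryl group on the five-membered aromatic ring changes.

No direction or size can be drawn from the numbers, since both measured values are limits (the limit of > 25000 nM in this assay, at which 2 of the 2 values shown sit). With compound 1 and compound 2 at the same limit, compound 3 is expected to remain there as well, with a step that the limit leaves unreadable from compound 2 to compound 3 amounting to no step beyond the scatter. For compound 3 the estimate in this assay is 35000 nM, within 10000 nM to 120000 nM.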

Compound 3, half-maximal inhibitory concentration: > 25000 nM
Compound 3: only a limit was reported; the forecaster's own chance of this, stated with the estimate: 80%; the middle value lies beyond the limit too.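

In this assay compound 3 returns > 25000 nM as a limit and not a number. Among the compounds shown here, no step from compound 1 or compound 2 to compound 3 can be read, since all the values shown are limits: the limit of > 25000 nM in this assay, at which 3 of the 3 values shown sit. The compounds shown leave open whether either swap, of aryl group or of amino for fluoro, changes antiproliferative activity at all.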